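Methyl-to-hydrogen exchange on the aryl oxygen of pyrazole ureas

A few compounds are considered here, and "the series" means these few. Any claim that something is new, unique, unknown or untested is made for them only; others in the source may bear on it.

Of the compounds shown here, three built around a shared core have been measured in a functional assay on PC-3 cells (Homo sapiens) for inhibition, read by sulforhodamine B assay, with a stated time of 48 h; on this read-out lower numbers stand for stronger inhibition and higher numbers for weaker inhibition. Compound 1, `COc1cc(-c2nn(-c3cccc(NC(=O)Nc4cc(C(F)(F)F)cc(C(F)(F)F)c4)c3)cc2-c2ccncc2)ccc1Cl`, gives 250 nM in this assay. Compound 2, `O=C(Nc1cccc(-n2cc(-c3ccncc3)c(-c3ccc(Cl)c(O)c3)n2)c1)Nc1cc(C(F)(F)F)cc(C(F)(F)F)c1`, gives 320 nM. Compound 3, `COc1cc(-c2nn(-c3cccc(NC(=O)Nc4ccc(Cl)c(C(F)(F)F)c4)c3)cc2-c2ccncc2)ccc1Cl`, gives 690 nM, the highest number of the three.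

Compounds 1 and 2 differ by one change, (hydrogen in place of methyl on an oxygen on an aromatic ring), and the step between them in this assay is a 1.3-fold higher number from compound 1 to compound 2 (0.11 log units; within the scatter). Compound 3 and compound 1 differ in more than one place, and the difference between the two cores is not broken down here.

Compound 4, `O=C(Nc1cccc(-n2cc(-c3ccncc3)c(-c3ccc(Cl)c(O)c3)n2)c1)Nc1ccc(Cl)c(C(F)(F)F)c1`, has not yet been measured in this assay. It differs from compound 3 by hydrogen in place of methyl on an oxygen on an aromatic ring, and the surroundings of the place where the change is made are the same as for the pair of compound 1 and compound 2, so this is the same change. Because the earlier step of a 1.3-fold higher number from compound 1 to compound 2 (0.11 log units; within the scatter) stayed within the scatter, the step from compound 3 to compound 4 is expected to be small as well, around a 1.2-fold higher number from compound 3 to compound 4 (0.09 log units; within the scatter). Compound 4 is therefore estimated to give 850 nM in this assay, with the likely range running from 400 nM to 1800 nM; this rests on a single earlier example of the change and on the value of compound 3 alone.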

Compound 4, half-maximal inhibitory concentration: 590 nM
Compound 4: middle estimate off by 1.4-fold (0.16 log units), on the high side; low and high end bracket the measured number.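

The exchange of methoxy for hydroxy on the 4-chloro-3-methoxyphenyl group also produced only a small step on the second core, with this assay giving a 1.2-fold lower number from compound 3 to compound 4 (0.07 log units; within the scatter). Set side by side, the two steps do not differ by more than the scatter expected for such a comparison: the same change on two cores in this assay, a 1.3-fold higher number (0.11 log units; within the scatter) from compound 1 to compound 2 and a 1.2-fold lower number (0.07 log units; within the scatter) from compound 3 to compound 4, 1.5-fold (0.18 log units) apart, within the scatter of two such steps. This shows that, in these two pairs, the change could be carried from one core to the other without a step beyond the scatter, but it gives no reliable direction for the change, and two pairs cannot show that the same would hold on other cores in the series or in another read-out.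

The compounds shown leave open how the number would respond if the oxygen carried an ethyl group or a longer chain, or if an amine took the place of the hydroxy group. They also leave open whether the exchange would remain this small on a core carrying a carboxylic acid or a nitrile in place of the chloro group on the same phenyl ring.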